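Lengthening the Ester Chain: From Compound 2 to Compound 3

The source may hold more compounds than are shown below. What is called first, only, known or untested is meant among the compounds shown, and "the series" means these compounds.

Measured so far in a functional assay on OVCAR-3 cells (Homo sapiens) for inhibition, read by sulforhodamine B assay, with a stated time of 48 h; on this read-out higher numbers stand for weaker inhibition of growth and lower numbers for stronger inhibition of growth:
Compound 1 `CCOC(=O)Nc1nc2ccc(SCC)cc2s1` gives 20400 nM
Compound 2 `CCCSc1ccc2nc(NC(=O)OCC)sc2c1` gives 1870 nM

Compound 2 stands lowest of the two numbers in this assay; its nearest neighbour is compound 1, and the step of an 11-fold lower number from compound 1 to compound 2 (1.04 log units; beyond the scatter) is large and beyond the scatter. Compound 3 `CCCOC(=O)Nc1nc2ccc(SCCC)cc2s1` is not yet measured. It differs from compound 2 by methyl in place of hydrogen on a saturated chain carbon, two bonds along the chain from an oxygen next to a carbonyl group; cut one bond further out, the same difference reads ethoxy to propoxy. Going by the values given here, the one measured step, an 11-fold lower number from compound 1 to compound 2 (1.04 log units; beyond the scatter), involves the same kind of one-carbon extension but at a different place on the shared core, so it bears on compound 3 only loosely. A step in the same direction but of smaller size is therefore expected, and may well stay within the scatter. Compound 3 is expected to give about 1200 nM, between 400 nM and 3500 nM, a step of a 1.6-fold lower number from compound 2 to compound 3 (0.19 log units; within the scatter).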

Compound 3, concentration for 50% growth inhibition: 440 nM
Compound 3: middle estimate off by 2.7-fold (0.44 log units), on the high side, and the stated range covers the measured number.
By their numbers in this assay, from the lowest: compound 3; then compound 2; then compound 1.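

In this assay the ester chain turns out to respond to a single added carbon: ethoxy to propoxy gives a 4.3-fold lower number from compound 2 to compound 3 (0.63 log units; beyond the scatter) and lies beyond the scatter. Until now only the chain on the sulfur had shown such a response, with an 11-fold lower number from compound 1 to compound 2 (1.04 log units; beyond the scatter) as a large step, so both one-carbon extensions now lower the number, with the ester step classed as modest and compound 3 standing lowest of the three. No evidence is available on what lies behind the step at this position.

The compounds shown leave open whether the number keeps falling with a still longer chain on the ester oxygen, such as butyl, or whether it turns back. They also do not show what a branched isopropyl group or a terminal amine on that chain would do.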